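The source may report more compounds than this note shows. Statements on the series, on what has been measured and on what is new or still open speak of the compounds shown alone.

Working notes on the series, as read in a functional assay on A-375 cells (Homo sapiens) for cytotoxicity, read by MTT assay; on this read-out lower numbers stand for stronger inhibition and higher numbers for weaker inhibition. Going by the values given here, compound 1 `CCC(=O)Oc1cc(/C=C/C(=O)c2ccc(OC)c3c2OC(C)(C)C=C3)ccc1OC` gives 240 nM and compound 2 `COc1cccc(C(=O)Oc2cc(/C=C/C(=O)c3ccc(OC)c4c3OC(C)(C)C=C4)ccc2OC)c1` gives 800 nM, so compound 2 holds the higher of the two numbers so far. Next comes compound 3 `COc1ccc(/C=C/C(=O)c2ccc(OC)c3c2OC(C)(C)C=C3)cc1OS(=O)(=O)Cc1ccccc1`, not yet measured. Its difference from compound 2 is benzylsulfonyl in place of (3-methoxyphenyl)carbonyl on an oxygen on an aromatic ring. In words, benzylsulfonyl stands in place of (3-methoxyphenyl)carbonyl on an oxygen on an aromatic ring.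

Among the compounds with values here, only one measured step bears on this: a 3.3-fold higher number from compound 1 to compound 2 (0.52 log units; beyond the scatter), a modest change beyond the scatter, with 3-methoxyphenyl in place of ethyl on a carbonyl carbon. That step shows that the group carried on this oxygen can move the number, but it changes only what sits on the carbonyl. Within the data shown here, no measured compound carries a sulfonyl group, so the direction rests on little. In this assay, a change no larger than that modest step is expected, most likely inside the scatter, with a slight lean towards a lower number. The expected step is a 1.3-fold lower number from compound 2 to compound 3 (0.12 log units; within the scatter). The estimate for compound 3 is 600 nM, with an expected range of 180 nM to 2000 nM.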

Compound 3, half-maximal inhibitory concentration: > 10000 nM
Compound 3: a limit, no number; the forecaster's own chance of this, stated with the estimate: 3%; middle value at least 16-fold (1.22 log units) from the limit.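

The value for compound 3 in this assay is a limit of the assay and not a number: the limit of > 10000 nM in this assay, at which 1 of the 3 values shown sits.

This oxygen on an aromatic ring tolerates less than the two carbonyl-linked compounds suggested, since benzylsulfonyl in place of (3-methoxyphenyl)carbonyl gives an at least 12-fold higher number from compound 2 to compound 3 (1.09 log units; beyond the scatter), and benzylsulfonyl in place of propanoyl gives an at least 41-fold higher number from compound 1 to compound 3 (1.61 log units; beyond the scatter). Both steps are large and exceed the modest 3.3-fold higher number from compound 1 to compound 2 (0.52 log units; beyond the scatter), the only change shown within the carbonyl-linked pair. The leaving (3-methoxyphenyl)carbonyl and the entering benzylsulfonyl match in heavy-atom count, aromatic ring count, and hydrogen-bond donor and acceptor counts, so these counts do not separate compound 2 from compound 3.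

Compound 3 changes the link to the oxygen and the group carried on it in a single step, so the compounds shown cannot say which of the two goes with the higher reading; a phenylacetyl or a methylsulfonyl group on this oxygen would part them. Going by these compounds, the full size of both new steps also stays open, since each rests on a limit.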